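This account rests on a few compounds, and the source may have more. Where it says the series, first, only, none or still open, it means among the compounds named here.

The shared core of compound 1 `COC(=O)c1sccc1NC(=O)CSc1cccc(OC)c1`, compound 2 `COC(=O)c1sccc1NC(=O)CCSc1ccccc1` and compound 3 `COC(=O)c1sccc1NC(=O)COc1ccc(Br)cc1` is the same, and the three differ in what hangs from the amide. In an assay on H9c2 cells for inhibition of tumor necrosis factor receptor superfamily member 6 (Rattus norvegicus), with stated times of 30 min and 6 h (a higher number here means that more compound is needed for the effect, a lower number that less compound is needed), compound 1 gives 575 nM. In this assay compound 2 gives 501 nM, and compound 3 gives 891 nM. Compound 2 therefore sits alongside compound 1 and compound 3, with gaps to both that fall within the scatter of repeated measurements, so the three are not separated by these numbers.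

Compound 4 `COC(=O)c1sccc1NC(=O)CCSc1ccc(Br)cc1` differs from compound 2 in one place: bromo in place of hydrogen on an aromatic carbon. Going by the values given here, no pair among the measured compounds shows this exact change by itself. Compound 3 carries a bromo group at the corresponding place of its ring, but it also has a different link between the amide and the ring, so its value is not a clean guide. On what is shown, the step from compound 2 to compound 4 is expected to be small, without a clear direction, and to stay within the scatter, with a 1.1-fold higher number from compound 2 to compound 4 (0.04 log units; within the scatter) as the expected size. Compound 4 is accordingly expected to give about 550 nM in this assay, within a range from 220 nM to 1400 nM, and the measurement now follows.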

Compound 4, half-maximal effective concentration: 1290 nM
Compound 4: middle estimate off by 2.3-fold (0.37 log units), on the low side, and the stated range covers the measured number.
By their numbers in this assay, from the lowest: compounds 2, 1, 3 and 4 (each within the scatter of the next, the first and the last beyond it).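

In this assay, the change from phenyl to 4-bromophenyl comes with a 2.6-fold higher number from compound 2 to compound 4 (0.41 log units; beyond the scatter), so a ring carbon para to a large group is not indifferent to what stands on it: with bromo there, more compound is needed for the effect. This is the only change among the compounds shown that can be read by itself, since compound 3 also carries bromo on its ring but has a different link between the amide and the ring, and it therefore cannot show whether the same change would have the same effect with that link. No measurement is available that bears on why the number rises with this change.

The compounds shown leave open whether the rise is particular to bromo, or whether chloro, fluoro, an amine or a carboxylic acid at the same ring carbon would move the number in the same direction or the other way. They also leave open whether bromo would have a similar effect at another place on the ring, or with a longer chain between the amide and the ring.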